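The source may hold more compounds than are shown below. What is called first, only, known or untested is meant among the compounds shown, and "the series" means these compounds.

Three compounds share one core and differ only in the group carried on the amide-type nitrogen at the far end. Compound 1 `COc1cc(Cl)cc(-c2nn(-c3cccc(NC(=O)Nc4ccc(Cl)c(C(F)(F)F)c4)c3)cc2-c2ccncc2)c1`, in a functional assay on OVCAR-5 cells (Homo sapiens) for inhibition, read by sulforhodamine B assay, with a stated time of 48 h, tested at 1 uM (a lower number here means a stronger effect, a higher number a weaker effect of the compound at the concentration tested), gives 81%. Compound 2 `COc1cc(Cl)cc(-c2nn(-c3cccc(NC(=O)Nc4ccc(Cl)c(Cl)c4)c3)cc2-c2ccncc2)c1` gives 87%, and compound 3 `COc1cc(Cl)cc(-c2nn(-c3cccc(NC(=O)Nc4cccc(C(F)(F)F)c4)c3)cc2-c2ccncc2)c1` gives 88%. Compound 3 holds the highest of the three numbers, yet the gaps are small: a number 7 percentage points higher from compound 1 to compound 3 (within the scatter) and a number 1 percentage points higher from compound 2 to compound 3 (within the scatter), both within the scatter, as is a number 6 percentage points higher from compound 1 to compound 2 (within the scatter).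

Compound 4 `COc1cc(Cl)cc(-c2nn(-c3cccc(NC(=O)c4cccc(C(F)(F)F)c4)c3)cc2-c2ccncc2)c1` is not yet measured. It differs from compound 3 in one place: 3-(trifluoromethyl)phenyl in place of (3-(trifluoromethyl)phenyl)amino on a carbonyl carbon. Within the data shown here, this change touches the carbonyl carbon itself, whereas every measured step swapped substituents on the outer ring, so no measured step bears on it directly. All three measured steps stayed within the scatter, giving no sign of a large effect from this region. The expected step in this assay is therefore a number 2 percentage points higher from compound 3 to compound 4 (within the scatter), not beyond the scatter, with wide uncertainty. Compound 4 is estimated at 90%, ranging from 72% to 102%.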

Compound 4, a percentage reported as activity, at one concentration (the size of the read-out at that concentration, not a potency): 96%
Beside the measured number, compound 4's estimate is 6 percentage points below it; the range from low to high includes it.
By their numbers in this assay, from the lowest: compounds 1, 2, 3 and 4 (each within the scatter of the next, the first and the last beyond it).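

Among these compounds, this is the first change at the carbonyl carbon itself, not on the outer ring: in this assay, removing the amino nitrogen, with its hydrogen-bond donor, gives a number 8 percentage points higher from compound 3 to compound 4 (within the scatter), and a number 9 percentage points higher from compound 2 to compound 4 (within the scatter), so neither step stands clear of the usual scatter. Only a number 15 percentage points higher from compound 1 to compound 4 (beyond the scatter) goes further, a modest weakening of the effect, but that step also loses the chloro group, so the two changes cannot be told apart. Nothing available explains this result.

The compounds shown leave open whether the amino nitrogen itself matters, which a methylene group or an oxygen atom in its place could test. They also leave open how a shorter group on the carbonyl carbon, such as methyl, would behave without the outer ring.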